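The source may hold more compounds than are shown below. What is called first, only, known or untested is meant among the compounds shown, and "the series" means these compounds.

In a functional assay on CAL-27 cells (Homo sapiens) for cytotoxicity, read by MTT assay, with a stated time of 72 h (on this read-out lower numbers stand for stronger inhibition and higher numbers for weaker inhibition), compound 2 `Nc1ccccc1NC(=O)CCCCCN(CC(=O)NCc1ccccc1)C(=O)c1cccc2ccccc12` gives 11000 nM. This lies within the scatter of compound 1 `Cc1cc(C)cc(C(=O)N(CCCCCC(=O)Nc2ccccc2N)CC(=O)NC2CCCCC2)c1`, which gives 17500 nM. Compound 3 `Nc1ccccc1NC(=O)CCCCCN(CC(=O)NC1CCCCC1)C(=O)c1cccc2ccccc12` gives 24900 nM, with a 2.3-fold higher number from compound 2 to compound 3 (0.35 log units; beyond the scatter).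

Next in the series is compound 4 `Cc1cc(C)cc(C(=O)N(CCCCCC(=O)Nc2ccccc2N)CC(=O)NCc2ccccc2)c1`: 3,5-dimethylphenyl in place of naphthalen-1-yl on a carbonyl carbon. Among the measured compounds shown here, the one measured step exchanging these two groups runs in the opposite sense and on the cyclohexyl amides: a 1.4-fold higher number from compound 1 to compound 3 (0.15 log units; within the scatter). On that evidence, no step beyond the scatter is expected in this assay. The expected step is a 1.2-fold lower number from compound 2 to compound 4 (0.09 log units; within the scatter). Compound 4 is estimated at 9000 nM, with an expected range of 4500 nM to 18000 nM.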

Compound 4, half-maximal inhibitory concentration: 13700 nM
Compound 4: the middle estimate sits 1.5-fold (0.18 log units) below what was measured, within the range that was stated.
By their numbers in this assay, from the lowest: compounds 2, 4, 1 and 3 (each within the scatter of the next, the first and the last beyond it).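

With the benzyl amide, 3,5-dimethylphenyl in place of naphthalen-1-yl on a carbonyl carbon gives a 1.2-fold higher number from compound 2 to compound 4 (0.10 log units; within the scatter), so in this assay this exchange now reads within the scatter on two cores, with no measurable dependence on the core: the same change on two cores in this assay, a 1.4-fold higher number (0.15 log units; within the scatter) from compound 1 to compound 3 and a 1.2-fold lower number (0.10 log units; within the scatter) from compound 4 to compound 2, 1.8-fold (0.25 log units) apart, within the scatter of two such steps. Benzyl in place of cyclohexyl on an amide-type nitrogen gives a 1.3-fold lower number from compound 1 to compound 4 (0.11 log units; within the scatter), and this change, too, does not separate between the two cores: the same change on two cores in this assay, a 2.3-fold higher number (0.35 log units; beyond the scatter) from compound 2 to compound 3 and a 1.3-fold higher number (0.11 log units; within the scatter) from compound 4 to compound 1, 1.8-fold (0.25 log units) apart, within the scatter of two such steps.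

Open, as far as these compounds go, is whether an aminophenyl group or a pyridin-3-yl ring in place of these aromatic groups on the carbonyl carbon would move the number beyond the scatter.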